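The compounds below may be only part of what the source reports. "The series", "measured", "known", "first", "only" and "open" are said of these compounds alone.

Of the compounds shown here, three have so far been measured in a functional assay (B cells) with Mus musculus as the target; on this read-out lower numbers stand for an effect already at smaller amounts and higher numbers for an effect only at larger amounts of compound. Compound 1, `NCC(O)Cn1c(=O)n(C2OC(CO)[C@@H](O)[C@H]2O)c2nc(N)nc(O)c21`, gives 28 uM in this assay, the highest of the three numbers. Compound 2, `C=CCn1c(=S)n(COCCO)c2nc(N)nc(O)c21`, gives 14 uM in this assay, a number within the usual scatter of that of compound 1, so the two cannot be ranked. Compound 3, `C=CCn1c(=O)n(CCCC)c2nc(N)nc(O)c21`, gives 2 uM in this assay, and its gap to compound 1 lies well beyond the scatter. Compound 3 carries butyl on an aromatic nitrogen where compound 1 carries 3-amino-2-hydroxypropyl, but the two also differ elsewhere, so no single change can be read from that pair.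

Compound 4, `CCCCn1c(=O)n(C2OC(CO)[C@@H](O)[C@H]2O)c2nc(N)nc(O)c21`, is not yet measured. It differs from compound 1 in one place: propyl in place of 2-amino-1-hydroxyethyl on a saturated chain carbon bound to an aromatic nitrogen. Because compound 3 gives 2 uM in this assay while carrying butyl on the corresponding nitrogen, a move toward lower numbers is expected for compound 4, though the other differences in compound 3 leave this uncertain. The step of a 2.8-fold lower number from compound 1 to compound 4 (0.45 log units; beyond the scatter) is estimated to be moderate. Compound 4 is expected to give about 10 uM in this assay, with a likely range from 3 uM to 35 uM.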

Compound 4, concentration for half-maximal effect: 11 uM
Compound 4: the middle estimate sits 1.1-fold (0.04 log units) below what was measured, within the range that was stated.
By their numbers in this assay, from the lowest: compound 3; then compounds 4, 2 and 1 (each within the scatter of the next, the first and the last beyond it).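

In this assay, among the compounds shown here, exchanging 3-amino-2-hydroxypropyl for butyl on the shared core gives a 2.5-fold lower number from compound 1 to compound 4 (0.41 log units; beyond the scatter), the first change at this place that can be read on its own. The chain that leaves carries hydrogen-bond donors and acceptors and the chain that enters carries none, so neither the amine nor the hydroxyl is required at this place for an effect on this read-out. For the compounds shown here, nothing measured so far accounts for the size of the step.

The step removes the amine and the hydroxyl together, so their separate contributions remain unresolved, and a 2-hydroxypropyl or a 3-aminopropyl chain at this place would tell them apart. On these data alone, it also remains open whether a longer chain, such as hexyl, would shift the number further.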